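A few compounds are considered here, and "the series" means these few. Any claim that something is new, unique, unknown or untested is made for them only; others in the source may bear on it.

Compound 1 `Cc1cc(C)cc(S(=O)(=O)c2c(C(=O)NN3CCOC3=O)[nH]c3ccc(Cl)cc23)c1`: > 100 uM (a limit)
Compound 2 `CC(=O)NNC(=O)c1[nH]c2ccc(Cl)cc2c1S(=O)(=O)c1cc(C)cc(C)c1`: > 100 uM (a limit)

In a functional assay on cells (Macrophage, Homo sapiens) for cytotoxicity (a lower number here means that less compound is tolerated, a higher number that more compound is tolerated), compound 2 stands at > 100 uM, which is a limit and not a number. Compound 3 `CCOC(=O)NNC(=O)c1[nH]c2ccc(Cl)cc2c1S(=O)(=O)c1cc(C)cc(C)c1` carries one change from compound 2, (ethoxy in place of methyl on a carbonyl carbon), with ethoxy in place of methyl on a carbonyl carbon. Going by the values given here, the one measured step, a step that the two limits leave unreadable from compound 1 to compound 2, gives no size to carry over. Among the compounds with values here, the only guide is the shared ceiling: the limit of > 100 uM in this assay, at which 2 of the 2 values shown sit. The estimated a number no higher from compound 2 to compound 3 (the limit leaves the size open) is expected to lie within the scatter in this assay, with no direction expected. For compound 3 the expected value is 100 uM, with an estimated range of 40 uM to 200 uM, most likely reported again as a limit.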

Compound 3, half-maximal toxic concentration: > 100 uM
Compound 3 ended at the assay's limit; the forecaster's own chance of this, stated with the estimate: 80%; the middle value sits exactly at the limit.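

No step among compound 1, compound 2 and compound 3 can be read in this assay, as each result is a limit and not a number: the limit of > 100 uM in this assay, at which 3 of the 3 values shown sit.

Whether these three compounds differ in tolerated concentration stays open, and no compound shown gives a number.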